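The source may report more compounds than this note shows. Statements on the series, on what has been measured and on what is new or still open speak of the compounds shown alone.

Compound 1 `CC/C(=C(/c1ccccc1)c1ccc(NC(=O)C(C)C)cc1)c1ccccc1` and compound 2 `CC/C(=C(/c1ccccc1)c1ccc(NC(=O)C(C)C)cc1)c1ccc(Cl)cc1Cl` differ in one place: 2,4-dichlorophenyl in place of phenyl on a double-bonded chain carbon bound to a double-bonded chain carbon and a saturated chain carbon. In a functional assay on HeLa cells (Homo sapiens) for inhibition, read by trypan blue exclusion, with a stated time of 72 h (a lower number here means a stronger inhibitor of growth, a higher number a weaker inhibitor of growth), compound 1 gives 28100 nM, and compound 2 gives 8200 nM, so this change made a 3.4-fold lower number from compound 1 to compound 2 (0.53 log units; beyond the scatter). Compound 3 `CC/C(=C(\c1ccc(O)cc1)c1ccc(NC(=O)C(C)C)cc1)c1ccccc1` carries a different core; how its core differs from that of compound 1 is not broken down here. In this assay compound 3 gives 9900 nM, which is within the scatter of the value of compound 2, while compound 1 gives a higher number than compound 3 by a gap beyond the scatter. Compound 4 `CC/C(=C(\c1ccc(O)cc1)c1ccc(NC(=O)C(C)C)cc1)c1ccc(Cl)cc1Cl` is the unmeasured partner of compound 3, made by the same change that turned compound 1 into compound 2: 2,4-dichlorophenyl in place of phenyl on a double-bonded chain carbon bound to a double-bonded chain carbon and a saturated chain carbon. The place of the change is described in the same words for both pairs, on a double-bonded chain carbon bound to a double-bonded chain carbon and a saturated chain carbon, so it is the same change on a second core. Within the data shown here, its only precedent is the single step from compound 1 to compound 2. Resting on that precedent, and on the value of compound 3 in this assay of 9900 nM, the author expects the step from compound 3 to compound 4 to be about a 3.3-fold lower number from compound 3 to compound 4 (0.52 log units; beyond the scatter), with less confidence than a repeated change would give. Compound 4 is therefore estimated to give 3000 nM in this assay, within a range from 1300 nM to 7000 nM.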

Compound 4, concentration for 50% growth inhibition: 8700 nM
For compound 4 the middle estimate is 2.9-fold (0.46 log units) below the measured one, outside the stated range (above it).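

On the second core, 2,4-dichlorophenyl in place of phenyl gave a 1.1-fold lower number from compound 3 to compound 4 (0.06 log units; within the scatter) in this assay, so the step seen on the first core did not carry over in size, and the two steps differ: the same change on two cores in this assay, a 3.4-fold lower number (0.53 log units; beyond the scatter) from compound 1 to compound 2 and a 1.1-fold lower number (0.06 log units; within the scatter) from compound 3 to compound 4, 3.0-fold (0.48 log units) apart, beyond the scatter of two such steps This shows that, for these two cores, the size of the step depends on the core that carries the change, and that one earlier pair was not a safe guide to a second pair in this series. It does not show which feature of the two cores accounts for the difference, and two pairs give no rule for how the same change would behave on any further core.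

The compounds shown leave open whether a fluorine atom or a methyl group in place of the chlorine atoms on that ring would also give steps that differ between the two cores. They also leave open whether a longer chain on the amide carbonyl, or a methoxy group in place of the hydroxyl group, would alter the step from phenyl to 2,4-dichlorophenyl in this assay.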